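A few compounds are considered here, and "the series" means these few. Any claim that something is new, unique, unknown or untested is made for them only; others in the source may bear on it.

Measured so far in a functional assay on HCT-116 cells (Homo sapiens) for cytotoxicity, read by MTT assay, with a stated time of 72 h; on this read-out higher numbers stand for weaker inhibition and lower numbers for stronger inhibition:
compound 1, `NS(=O)(=O)c1cc(-c2nnc(Cn3cc(-c4ccccc4)nn3)o2)c(Cl)cc1SCc1ccccc1`: compound 1 gives 75000 nM
compound 2, `NCc1nnc(-c2cc(S(N)(=O)=O)c(SCc3ccccc3)cc2Cl)o1`: compound 2 gives 120000 nM
compound 3, `NS(=O)(=O)c1cc(-c2nnc(/C=C/c3ccccc3)o2)c(Cl)cc1SCc1ccccc1`: compound 3 gives 18000 nM

Compound 3 stands lowest of the three numbers. The steps of a 4.2-fold lower number from compound 1 to compound 3 (0.62 log units; beyond the scatter) and a 6.7-fold lower number from compound 2 to compound 3 (0.82 log units; beyond the scatter) both reach beyond the scatter, whereas a 1.6-fold higher number from compound 1 to compound 2 (0.20 log units; within the scatter) does not, so the 2-phenylethenyl group on the shared core marks the only clear gain seen so far.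

Compound 4, `NS(=O)(=O)c1cc(-c2nnc(/C=C/c3ccc(Br)cc3)o2)c(Cl)cc1SCc1ccccc1`, differs from compound 3 by bromo in place of hydrogen on an aromatic carbon. For the measured compounds named here, no measured step touches this position: the two steps that lead to compound 3 exchange the whole group on the shared core, and none of the measured compounds carries a substituent on the phenyl ring of the 2-phenylethenyl group. Nothing in the series therefore speaks for a step beyond the scatter in either direction, and the working expectation is that compound 4 sits near compound 3.

The expected step is a 1.2-fold lower number from compound 3 to compound 4 (0.08 log units; within the scatter), within the scatter. For compound 4 the estimate in this assay is 15000 nM, with a range from 5000 nM to 45000 nM.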

Compound 4, half-maximal inhibitory concentration: 15000 nM
Compound 4: the middle estimate sits on the measured number at the digits printed, within the range that was stated.
By their numbers in this assay, from the lowest: compounds 4 and 3 (each within the scatter of the next); then compounds 1 and 2 (each within the scatter of the next).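

In this assay, for the compounds shown here, bromo is the first substituent seen on the phenyl ring of the 2-phenylethenyl group, and at this place, para to a large group, a 1.2-fold lower number from compound 3 to compound 4 (0.08 log units; within the scatter) stays within the scatter, so the number does not separate compound 4 from compound 3. The 2-(4-bromophenyl)ethenyl group also stands clear of the other groups on the shared core, with an 8.0-fold lower number from compound 2 to compound 4 (0.90 log units; beyond the scatter) against aminomethyl and a 5.0-fold lower number from compound 1 to compound 4 (0.70 log units; beyond the scatter) against (4-phenyl-1H-1,2,3-triazol-1-yl)methyl, both beyond the scatter. No evidence at hand accounts for the number holding when bromo enters.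

With a single substituent at a single place on this ring, the compounds shown leave open how a methoxy group, an amine or a carboxylic acid would read there. Also open, going by these compounds, is how a longer chain would read in place of the ethenyl link.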